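Removing the Alkenyl Ether Leaves a Free Phenol

The compounds below may be only part of what the source reports. "The series", "measured", "known", "first", "only" and "open" are said of these compounds alone.

compound 1 `C=C(C)CCOc1c(OC)cc(/C=C/CO)cc1OC`: > 100000 nM
compound 2 `CC(C)=CCOc1ccc(C(=O)/C=C/c2ccc(O)cc2)c(O)c1`: > 100000 nM
compound 3 `COc1cc(/C=C/CO)ccc1OC/C=C(\C)CCC=C(C)C`: 31000 nM

Of the compounds shown here, three have been measured in a functional assay on SK-MEL-28 cells (Homo sapiens) for cytotoxicity, read by MTT assay, with a stated time of 72 h; a lower number here means a stronger inhibitor, a higher number a weaker inhibitor. Compound 1 gives only a limit there, > 100000 nM. Compound 2 also gives only a limit, > 100000 nM. Compound 3 gives a number, 31000 nM. Compound 1 stands at the limit of > 100000 nM in this assay, at which 2 of the 3 values shown sit. The unmeasured compound 4 `COc1cc(/C=C/CO)cc(OC)c1O` differs from compound 1 in one place: hydrogen in place of 3-methylbut-3-en-1-yl on an oxygen on an aromatic ring. No step between two measured compounds is known, so the size of this change cannot be read from the numbers shown; compound 1 offers only a limit, and the expectation for compound 4 is that it stays at or near that limit, with no step beyond the scatter in this assay. Compound 4 is expected to give about 100000 nM, between 30000 nM and 300000 nM, an expected step of a number no higher from compound 1 to compound 4 (the limit leaves the size open).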

Compound 4, half-maximal inhibitory concentration: > 100000 nM
Compound 4 ended at the assay's limit (the forecaster's own chance of this, stated with the estimate: 70%); the middle value sits exactly at the limit.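

No step can be read from compound 1 to compound 4, as both give only a limit: the limit of > 100000 nM in this assay, at which 3 of the 4 values shown sit.

As far as these compounds go, whether hydrogen in place of 3-methylbut-3-en-1-yl on that oxygen changes potency in this assay stays open.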